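Branching the Ester: From Isopentyl to tert-Butyl

This account rests on a few compounds, and the source may have more. Where it says the series, first, only, none or still open, it means among the compounds named here.

Three compounds share one core and differ only in the group on an oxygen next to a carbonyl group. Compound 1 `COC(=O)NS(=O)(=O)c1sc(CC(C)C)cc1-c1cccc(Cn2ccnc2)c1` carries a methyl there, and in an assay on HEK293 cells for displacement of a labelled ligand from Type-2 angiotensin II receptor (Homo sapiens), read by scintillation counting, with a stated time of 240 min (on this read-out lower numbers stand for stronger inhibition and higher numbers for weaker inhibition), compound 1 gives 400 nM. Compound 2 `CC(C)Cc1cc(-c2cccc(Cn3ccnc3)c2)c(S(=O)(=O)NC(=O)OC(C)C)s1` carries an isopropyl, and compound 2 gives 160 nM. Compound 3 `CC(C)CCOC(=O)NS(=O)(=O)c1sc(CC(C)C)cc1-c1cccc(Cn2ccnc2)c1` carries an isopentyl, and compound 3 gives 230 nM, the second highest of the three numbers, although its gaps to both others stay within the scatter: a 1.7-fold lower number from compound 1 to compound 3 (0.24 log units; within the scatter) and a 1.4-fold higher number from compound 2 to compound 3 (0.16 log units; within the scatter). Among the measured compounds shown here, the only step beyond the scatter is a 2.5-fold lower number from compound 1 to compound 2 (0.40 log units; beyond the scatter).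

Compound 4 `CC(C)Cc1cc(-c2cccc(Cn3ccnc3)c2)c(S(=O)(=O)NC(=O)OC(C)(C)C)s1` is the next step: tert-butyl in place of isopentyl on an oxygen next to a carbonyl group. For the measured compounds named here, two measured steps bear on it. Lengthening the group from isopropyl to isopentyl changed little, as a 1.4-fold higher number from compound 2 to compound 3 (0.16 log units; within the scatter) shows, while the branched isopropyl in compound 2 gave the lowest number seen. A small step toward lower numbers is therefore expected, a 1.4-fold lower number from compound 3 to compound 4 (0.13 log units; within the scatter), likely within the scatter, because compound 2 gives 160 nM with a branched group. Compound 4 is estimated at 170 nM, with a range from 80 nM to 350 nM.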

Compound 4, inhibition constant: 270 nM
The estimate for compound 4 lay 1.6-fold (0.20 log units) below the measured number; low and high end bracket the measured number.
By their numbers in this assay, from the lowest: compounds 2, 3, 4 and 1 (each within the scatter of the next, the first and the last beyond it).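

In this assay, tert-butyl stays within the scatter of all three other groups: isopentyl (a 1.2-fold higher number from compound 3 to compound 4 (0.07 log units; within the scatter)), isopropyl (a 1.7-fold higher number from compound 2 to compound 4 (0.23 log units; within the scatter)) and methyl (a 1.5-fold lower number from compound 1 to compound 4 (0.17 log units; within the scatter)). Among the compounds shown here, the one step beyond the scatter, from methyl to isopropyl (a 2.5-fold lower number from compound 1 to compound 2 (0.40 log units; beyond the scatter)), therefore does not carry over to tert-butyl, although tert-butyl differs from isopropyl by only one added methyl, so a branched group at this position does not by itself separate from methyl. No measurement available here offers an explanation for this pattern.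

The compounds shown leave open how this position would respond to a ring, such as cyclohexyl or benzyl, or to a chain ending in an amine or a carboxylic acid. They also leave open where unbranched chains such as ethyl or butyl would fall relative to isopropyl.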